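This account rests on a few compounds, and the source may have more. Where it says the series, first, only, none or still open, it means among the compounds named here.

In an ADME assay on microsomes from liver (Mus musculus) for metabolic stability, read by HPLC, with a stated time of 30 min (on this read-out lower numbers stand for a less stable compound and higher numbers for a more stable compound), compound 1 (`Cc1ccc(NC(=O)C(=O)c2c[nH]c3cc(C)ccc23)cc1`) gives 90.2% and compound 2 (`COc1ccc(NC(=O)C(=O)c2c[nH]c3cc(Cl)ccc23)cc1`) gives 87.3% here, within the usual scatter of compound 1. Compound 3 (`Cc1ccc(NC(=O)C(=O)c2c[nH]c3cc(Cl)ccc23)cc1`) differs from compound 2 by having methyl in place of methoxy on an aromatic carbon, para to a large group (methyl in place of methoxy on an aromatic carbon). Within the data shown here, no measured pair differs in one place only, so no direct step is available to guide this change. The estimated a number 1.7 percentage points higher from compound 2 to compound 3 (within the scatter) in this assay is expected to stay within the scatter, in no clear direction. Compound 3 is expected at 89% with an estimated range from 78% to 97% on repeat measurements.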

Compound 3, percent of the compound remaining: 85.6%
Beside the measured number, compound 3's estimate is 3.4 percentage points above it; the measured number falls inside the stated range.
By their numbers in this assay, from the lowest: compounds 3, 2 and 1 (each within the scatter of the next).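

Methyl in place of methoxy on an aromatic carbon, para to a large group, gives a number 1.7 percentage points lower from compound 2 to compound 3 (within the scatter) in this assay and so the two groups cannot be told apart at this position. Chloro in place of methyl on an aromatic carbon gives a number 4.6 percentage points lower from compound 1 to compound 3 (within the scatter) and this second change also stays inside the normal spread of repeat measurements. Nothing available here explains either step.

On these data alone, whether an amine or a carboxylic acid at the para position would give a similar number remains open. So does the effect of a longer chain there.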